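A few compounds are considered here, and "the series" means these few. Any claim that something is new, unique, unknown or untested is made for them only; others in the source may bear on it.

Compound 1 `Cc1ccc2[nH]c(=O)c(CN(Cc3ccccc3)Cc3ccc(C(C)(C)C)cc3)cc2c1` gives > 5000 nM in a toxicity assay on MDCK cells (Canis lupus familiaris) for cytotoxicity, read by crystal violet staining, with a stated time of 48 h (on this read-out lower numbers stand for higher toxicity in this test and higher numbers for lower toxicity in this test), which is a limit of the assay and not a number.
Compound 2 `Cc1ccc2[nH]c(=O)c(CN(CCCO)Cc3ccc(C(C)(C)C)cc3)cc2c1` gives > 10000 nM in this assay, again a limit.
Compound 3 `CCCCOc1ccc(CN(Cc2ccc(C(C)(C)C)cc2)Cc2cc3cc(C)ccc3[nH]c2=O)cc1` gives > 5000 nM in this assay, also a limit.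

Compound 3 therefore stands at a limit, and no number places it among the others. Two of the three values sit at the limit of > 5000 nM in this assay, at which 2 of the 3 values shown sit, while the remaining one sits at the limit of > 10000 nM in this assay, at which 1 of the 3 values shown sits. The steps that lead into compound 3, a step that the two limits leave unreadable from compound 1 to compound 3 and a step that the two limits leave unreadable from compound 2 to compound 3, are accordingly unreadable, and the same holds for a step that the two limits leave unreadable from compound 1 to compound 2.

Compound 4 `Cc1ccc2[nH]c(=O)c(CN(Cc3ccc(N(C)C)cc3)Cc3ccc(C(C)(C)C)cc3)cc2c1` differs from compound 3 by dimethylamino in place of butoxy on an aromatic carbon. Both measured steps that bear on this kind of change at the benzyl arm of the amine, namely a step that the two limits leave unreadable from compound 1 to compound 3 and a step that the two limits leave unreadable from compound 2 to compound 3, give no readable size, so no direction can be drawn from them; in this assay all three compounds remain at a limit. Compound 4 is therefore expected to show a step that the limit leaves unreadable from compound 3 to compound 4, that is, none that can be read. The estimate for compound 4 in this assay is 10000 nM, with a range from 3000 nM to 30000 nM, most likely reported again as a limit.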

Compound 4, half-maximal cytotoxic concentration: > 5000 nM
Compound 4: no number, only a limit (the forecaster's own chance of this, stated with the estimate: 85%); the middle value is on the limit's open side.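

In this assay compound 4 gives > 5000 nM, which is a limit of the assay and not a number. Among the compounds shown here, no step between compound 4 and compound 1, compound 2 or compound 3 can therefore be read. The four compounds leave open at what concentration any of them becomes toxic in this assay, and whether any of these changes alters that concentration.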